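The source may report more compounds than this note shows. Statements on the series, on what has been measured and on what is new or still open speak of the compounds shown alone.

Compound 2 `CCNC(=O)CC1CCc2cc(OC)c(OC)cc21` gives 26.1% in a functional assay on the whole organism (strain Wistar) for inhibition, with Rattus norvegicus as the target, read by paw edema, with stated times of 60 min and 3 h, at a dose of 100 mg/kg by the oral route (on this read-out lower numbers stand for less inhibition and higher numbers for more inhibition at the one dose given (going by the name of the read-out)), and stands lowest of the two numbers measured, the nearest being compound 1 `COc1cc2c(cc1OC)C(CC(N)=O)CC2`, which in this assay gives 30.4%. Within the data shown here, the one step between them, a number 4.3 percentage points lower from compound 1 to compound 2 (within the scatter), lay within the scatter and covered ethyl in place of hydrogen on an amide-type nitrogen. Compound 3 `CCCCNC(=O)CC1CCc2cc(OC)c(OC)cc21` differs from compound 2 by ethyl in place of hydrogen on a saturated chain carbon, two bonds along the chain from an amide-type nitrogen. Among the measured compounds shown here, only that single step bears on this change, and since it stayed within the scatter, no step beyond the scatter is expected here. Compound 3 is therefore estimated at 26%, between 12% and 40%. This estimate means an expected step of a number 0.1 percentage points lower from compound 2 to compound 3 (within the scatter).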

Compound 3, a percentage reported as inhibition, in the whole organism at one dose (the size of the read-out at that dose, not a potency): 27.5%
Compound 3: the middle estimate sits 1.5 percentage points below what was measured, and the stated range covers the measured number.
By their numbers in this assay, from the lowest: compounds 2, 3 and 1 (each within the scatter of the next).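

In this assay, ethyl in place of hydrogen on a saturated chain carbon, two bonds along the chain from an amide-type nitrogen, gave a number 1.4 percentage points higher from compound 2 to compound 3 (within the scatter) and so separates butyl from ethyl at this position by no more than the scatter. Butyl in place of the amide hydrogen gave a number 2.9 percentage points lower from compound 1 to compound 3 (within the scatter) as its whole step, so the butyl amide too stands level with the amide of compound 1. Nothing available explains these small steps.

The compounds shown leave open whether an amine, a carboxylic acid or a phenyl ring on this nitrogen would give a step beyond the scatter. Going by these compounds, a longer chain also remains open.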